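The compounds below may be only part of what the source reports. "The series", "measured", "known", "first", "only" and "open" are said of these compounds alone.

Series measured in a functional assay on MCF7 cells (Homo sapiens) for antiproliferative activity, read by MTT assay, with a stated time of 48 h; on this read-out higher numbers stand for weaker inhibition and lower numbers for stronger inhibition:
- compound 1 `CC(=O)OC/C1=C/C[C@](C)(CCC=C(C)C)/C=C/[C@@H](OC(=O)C=C(C)C)[C@](C)(OC(C)=O)/C=C/C1=O` gives 3990 nM
- compound 2 `C=C1/C=C/C(=O)/C(CO)=C\C[C@](C)(CCC=C(C)C)/C=C/[C@H]1OC(=O)C=C(C)C` gives 2750 nM
- compound 3 `CCN(CC)C/C1=C/C[C@](C)(CCC=C(C)C)/C=C/[C@@H](OC(=O)C=C(C)C)[C@](C)(O)/C=C/C1=O` gives 130 nM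

Compound 3 has the lowest number of the three, well clear of the other two beyond the usual scatter. Compound 4 `CC(C)=CCC[C@]1(C)/C=C/[C@@H](OC(=O)C=C(C)C)[C@](C)(O)/C=C/C(=O)/C(COC(=O)c2ccc([N+](=O)[O-])cc2)=C\C1` departs from compound 3 by ((4-nitrophenyl)carbonyl)oxy in place of diethylamino on a saturated chain carbon bound to a double-bonded ring carbon, with ((4-nitrophenyl)carbonyl)oxy in place of diethylamino on a saturated chain carbon bound to a double-bonded ring carbon. Within the data shown here, no single-site step has been measured, so the only guide is that the two compounds without diethylamino, compound 1 at 3990 nM and compound 2 at 2750 nM, both show higher numbers than compound 3. A sizeable move to a higher number in this assay, beyond the scatter, is therefore expected, and the estimated step is a 12-fold higher number from compound 3 to compound 4 (1.06 log units; beyond the scatter). For compound 4 the estimated value is 1500 nM, with an expected range of 350 nM to 6000 nM.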

Compound 4, half-maximal inhibitory concentration: 670 nM
For compound 4 the middle estimate is 2.2-fold (0.35 log units) above the measured one; the range from low to high includes it.
By their numbers in this assay, from the lowest: compound 3; then compound 4; then compounds 2 and 1 (each within the scatter of the next).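

In this assay, among these compounds, the exchange of diethylamino for ((4-nitrophenyl)carbonyl)oxy on a saturated chain carbon bound to a double-bonded ring carbon gives the first single-place reading at this position, with a 5.2-fold higher number from compound 3 to compound 4 (0.71 log units; beyond the scatter) as a modest cost. This place therefore accepts a much larger aromatic group while diethylamino remains the better of the two groups here. No measurement at hand accounts for the step. Still open, from the compounds shown here alone, is whether the nitro group, the aromatic ring or the ester link drives the step, and how piperidine or unsubstituted benzoyloxy would read at this place.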